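Removing a Methyl from Two Urea Analogues

The compounds below may be only part of what the source reports. "The series", "measured", "known", "first", "only" and "open" are said of these compounds alone.

Compound 1 `COc1cc(-c2nn(-c3cccc(NC(=O)Nc4cc(C(F)(F)F)cc(C(F)(F)F)c4)c3)cc2-c2ccncc2)ccc1Cl` and compound 2 `COc1cc(-c2nn(-c3cccc(NC(=O)Nc4ccc(Cl)c(Cl)c4)c3)cc2-c2ccncc2)ccc1Cl` share much of their structure; the difference between the two cores is not broken down here. In a functional assay on MOLT-4 cells (Homo sapiens) for inhibition, read by sulforhodamine B assay, with a stated time of 48 h (on this read-out lower numbers stand for stronger inhibition of growth and higher numbers for weaker inhibition of growth), compound 1 gives 4480 nM and compound 2 gives 4480 nM, which sit level. Compound 3 `O=C(Nc1cccc(-n2cc(-c3ccncc3)c(-c3ccc(Cl)c(O)c3)n2)c1)Nc1ccc(Cl)c(Cl)c1` arises from compound 2 by hydrogen in place of methyl on an oxygen on an aromatic ring. For compound 3 this assay reports only a limit, > 32500 nM. That gives an at least 7.2-fold higher number from compound 2 to compound 3 (0.86 log units; beyond the scatter), a value resting on (the limit of > 32500 nM in this assay, at which 1 of the 3 values shown sits). Compound 4 `O=C(Nc1cccc(-n2cc(-c3ccncc3)c(-c3ccc(Cl)c(O)c3)n2)c1)Nc1cc(C(F)(F)F)cc(C(F)(F)F)c1` arises from compound 1 by the same change, (hydrogen in place of methyl on an oxygen on an aromatic ring). Because the step of an at least 7.2-fold higher number from compound 2 to compound 3 (0.86 log units; beyond the scatter) already ran past the limit, a step of comparable size seems likely here. For compound 4 the expected step is an 8.9-fold higher number from compound 1 to compound 4 (0.95 log units; beyond the scatter). Compound 4 is therefore estimated at 40000 nM, probably again outside the measurable window.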

Compound 4, concentration for total growth inhibition: 4360 nM
Compound 4: middle estimate off by 9.2-fold (0.96 log units), on the high side; the whole stated range lies above it.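

In this assay, putting hydroxy in place of methoxy on the core of compound 1 gives a 1.0-fold lower number from compound 1 to compound 4 (0.01 log units; within the scatter), so the result seen on the other core does not carry over, and the same change behaves differently on the two cores: the same change on two cores in this assay, an at least 7.2-fold higher number (0.86 log units; beyond the scatter) from compound 2 to compound 3 and a 1.0-fold lower number (0.01 log units; within the scatter) from compound 1 to compound 4, at least 7.4-fold (0.87 log units) apart, beyond the scatter of two such steps
The reading for compound 3 is a limit and not a number: the limit of > 32500 nM in this assay, at which 1 of the 4 values shown sits.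
These two pairs show that the outcome of this change depends on the core, but they do not show which part of the cores is responsible, or why.

Other cores remain open, so a wider rule cannot be drawn. Going by these compounds, it is also open how an ethoxy group or an amine would behave in place of the methoxy.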